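Chloro on the N-aryl ring of the thiophene analogue

The compounds below may be only part of what the source reports. "The series", "measured", "known", "first", "only" and "open" are said of these compounds alone.

Compound 3 `CC1(C)OC(=O)C2(C(=O)O1)C(c1cccs1)C(c1ccccc1)=NN2c1ccccc1` gives 585000 nM in a functional assay on aorta (Rattus norvegicus, strain Wistar) for inhibition; on this read-out lower numbers stand for stronger inhibition and higher numbers for weaker inhibition. This is the highest of the three numbers gathered so far, but neither neighbour is separated from it beyond the scatter: compound 1 `COc1ccc(C2C(c3ccccc3)=NN(c3ccccc3)C23C(=O)OC(C)(C)OC3=O)cc1` gives 500000 nM in this assay, and compound 2 `CN(C)c1ccc(C2C(c3ccccc3)=NN(c3cccc(Cl)c3)C23C(=O)OC(C)(C)OC3=O)cc1` gives 430000 nM in this assay. Among the measured compounds shown here, the one single-point step measured in the set, a 1.2-fold higher number from compound 1 to compound 3 (0.07 log units; within the scatter), shows that exchanging the aryl group on the saturated ring carbon leaves the read-out essentially unchanged.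

Compound 4 `CC1(C)OC(=O)C2(C(=O)O1)C(c1cccs1)C(c1ccccc1)=NN2c1cccc(Cl)c1` differs from compound 3 in one place: chloro in place of hydrogen on an aromatic carbon, on an aromatic carbon of a six-membered aromatic ring of carbon only, meta to a large group; cut one bond further out, the change reads phenyl to 3-chlorophenyl. For the measured compounds named here, no measured step isolates this change. Compound 2 does carry a 3-chlorophenyl on the same nitrogen, but it also carries a different aryl on the saturated carbon, so its value and that of compound 3 only show that both sit in the same region of this assay. Given the single measured step and the values of compound 2 and compound 3, no movement beyond the scatter is expected for compound 4, and the step from compound 3 to compound 4 is estimated as a 1.2-fold lower number from compound 3 to compound 4 (0.07 log units; within the scatter). The estimate for compound 4 in this assay is therefore 500000 nM, with a range from 250000 nM to 1000000 nM.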

Compound 4, half-maximal inhibitory concentration: 321000 nM
The estimate for compound 4 lay 1.6-fold (0.19 log units) above the measured number; the range from low to high includes it.
By their numbers in this assay, from the lowest: compounds 4, 2, 1 and 3 (each within the scatter of the next).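

Among the compounds shown here, this is the first measured reading of a chloro group entering on this aromatic carbon, meta to a large group: in this assay the change from phenyl to 3-chlorophenyl gives a step that stays within the scatter (a 1.8-fold lower number from compound 3 to compound 4 (0.26 log units; within the scatter)). With the 3-chlorophenyl group held constant, exchanging the aryl group on the saturated ring carbon also stays within the scatter (a 1.3-fold lower number from compound 2 to compound 4 (0.13 log units; within the scatter)), matching the reading with unsubstituted phenyl (a 1.2-fold higher number from compound 1 to compound 3 (0.07 log units; within the scatter)), so neither change separates these compounds in this assay, although the aryl groups leaving in the two exchanges differ. No available evidence bears on the size of these steps.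

Open, as far as these compounds go, is whether a nitrile, a methoxy group or a carboxylic acid at the same aromatic carbon would move the read-out beyond the scatter, or whether this position stays as flat with other groups as it does with chloro. Also open, from the compounds shown here alone, is whether an amine or a longer chain elsewhere on the shared core would separate any compound from this cluster of closely spaced values.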